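The source may report more compounds than this note shows. Statements on the series, on what has been measured and on what is new or still open speak of the compounds shown alone.

Three compounds that share a two-ring core are compared in a functional assay on IGROV-1 cells (Homo sapiens) for cytotoxicity, read by sulforhodamine B assay, with a stated time of 48 h; on this read-out higher numbers stand for weaker inhibition of growth and lower numbers for stronger inhibition of growth. In this assay compound 1 `ClCc1ccccc1Cn1cnc2c(Cl)nc(Cl)nc21` gives 1540 nM. Compound 2 `ClCc1cccc(Cn2cnc3c(Cl)nc(Cl)nc32)c1` is made of the same atoms joined differently; how the two differ is not broken down here. In this assay compound 2 gives 2290 nM, a number that lies within the usual scatter of the number for compound 1. Compound 3 `Nc1nc(Cl)c2ncn(Cc3ccccc3CCl)c2n1` differs from compound 1 by amino in place of chloro on an aromatic carbon. In this assay compound 3 gives 6310 nM, and that is a 4.1-fold higher number from compound 1 to compound 3 (0.61 log units; beyond the scatter).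

Compound 4 `Nc1nc(Cl)c2ncn(Cc3cccc(CCl)c3)c2n1` has not yet been measured. Within the data shown here, it differs from compound 2 by amino in place of chloro on an aromatic carbon, which is the same change at the same place as the one from compound 1 to compound 3. That change has been measured only once, so any expectation for compound 4 rests on that single step. Compound 4 is expected to show a 3.9-fold higher number from compound 2 to compound 4 (0.59 log units; beyond the scatter) because the step of a 4.1-fold higher number from compound 1 to compound 3 (0.61 log units; beyond the scatter) was of that size when the same change was made on the core of compound 1. The estimate for compound 4 is 9000 nM, with a likely range from 3500 nM to 22000 nM. Whether the change behaves the same way on the core of compound 2 is exactly what the measurement will show.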

Compound 4, concentration for 50% growth inhibition: 3460 nM
Estimate against measurement, compound 4: 2.6-fold (0.42 log units) above; measured number outside the range, below it.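

In this assay the swap of chloro for amino now gives a 1.5-fold higher number from compound 2 to compound 4 (0.18 log units; within the scatter), a step that cannot be told apart from repeat-to-repeat variation, so the clear rise in the number seen on the first core does not reappear on this one. Set side by side, the two steps differ in size, which means that this change cannot be carried from one core to the other as a fixed amount: the same change on two cores in this assay, a 4.1-fold higher number (0.61 log units; beyond the scatter) from compound 1 to compound 3 and a 1.5-fold higher number (0.18 log units; within the scatter) from compound 2 to compound 4, 2.7-fold (0.43 log units) apart, beyond the scatter of two such steps. Among these compounds, this does not show why the two cores respond differently, since they are made of the same atoms joined differently and only one matched pair exists for each, nor does it predict the size of the step on any further core.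

On these data alone, only chloro and amino appear on this aromatic carbon, so it remains open how a methylamino group or a methoxy group there would behave on either core. As far as these compounds go, it also remains open whether such groups would show the same difference between the two cores, or whether that difference is particular to the amino group and to these IGROV-1 cells.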